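This account rests on a few compounds, and the source may have more. Where it says the series, first, only, none or still open, it means among the compounds named here.

Measured so far in a functional assay on MKN-45 cells (Homo sapiens) for cytotoxicity, read by MTT assay, with a stated time of 72 h; on this read-out higher numbers stand for weaker inhibition and lower numbers for stronger inhibition:
compound 1 `CN(C)CCNc1nc(-c2ccc(NC(=O)Nc3ccccc3Cl)cc2)nc2c(Cl)c(Cl)sc12` gives 1170 nM
compound 2 `CCN(CC)CCCNc1nc(-c2ccc(NC(=O)Nc3ccccc3)cc2)nc2c(Cl)c(Cl)sc12` gives 1640 nM

Compound 2 holds the higher of the two numbers, yet its gap to compound 1 lies within the usual scatter, so the two compounds cannot be placed in order on this read-out. Compound 3 `CCN(CC)CCCNc1nc(-c2ccc(NC(=O)Nc3ccccc3Cl)cc2)nc2c(Cl)c(Cl)sc12` is the partner of compound 2 that differs in one place: chloro in place of hydrogen on an aromatic carbon, the same difference reading phenyl to 2-chlorophenyl, or phenylcarbamoyl to (2-chlorophenyl)carbamoyl, one bond further out. Compound 1 carries that same chloro group but also a different amine chain, so the two measured values give no isolated reading of the chloro change. With only this to go on, the step from compound 2 to compound 3 is expected to be small, a 1.5-fold lower number from compound 2 to compound 3 (0.17 log units; within the scatter), in no firm direction beyond the scatter. Compound 3 is therefore estimated at 1100 nM, with a range from 450 nM to 2700 nM.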

Compound 3, half-maximal inhibitory concentration: 1450 nM
Compound 3: the middle estimate sits 1.3-fold (0.12 log units) below what was measured; low and high end bracket the measured number.
By their numbers in this assay, from the lowest: compounds 1, 3 and 2 (each within the scatter of the next).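

In this assay, the chloro group on the aromatic carbon, ortho to a large group, can now be read on its own, and the change comes to a 1.1-fold lower number from compound 2 to compound 3 (0.05 log units; within the scatter) in this series. The amine chain can also be read on its own: with the 2-chlorophenyl group held fixed, (diethylamino)methyl in place of dimethylamino gives a 1.2-fold higher number from compound 1 to compound 3 (0.09 log units; within the scatter), so neither change separates these compounds on this read-out. Nothing measured on hand bears on these results.

The compounds shown leave open whether another group on this ring, such as methoxy or trifluoromethyl, would shift the number beyond the scatter. They also leave open whether a different amine at the end of the chain, such as morpholine or piperidine, would do so.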